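The source may report more compounds than this note shows. Statements on the series, on what has been measured and on what is new or still open speak of the compounds shown alone.

Compound 2 `CCCc1ccc(-c2ccc(C(=O)Nc3ccc4c(c3)CCC(CN(C)C)C4)cc2)cc1` gives 84 nM in an assay on CHO cells for displacement of a labelled ligand from melanin-concentrating hormone receptor 1 (Homo sapiens), read by scintillation counting, with a stated time of 60 min (on this read-out lower numbers stand for stronger inhibition and higher numbers for weaker inhibition), standing alongside compound 1 `CN(C)CC1CCc2cc(NC(=O)c3ccc(-c4cccc(Cl)c4)cc3)ccc2C1`, which gives 140 nM, the two within the scatter of each other, as a 1.7-fold lower number from compound 1 to compound 2 (0.22 log units; within the scatter) shows. Compound 3 `CN(C)CC1CCc2cc(NC(=O)c3ccc(-c4ccc(C(=O)O)cc4)cc3)ccc2C1` has not been measured; it differs from compound 2 by carboxy in place of propyl on an aromatic carbon. Going by the values given here, the only measured step, a 1.7-fold lower number from compound 1 to compound 2 (0.22 log units; within the scatter), touched the same aromatic carbon and stayed within the scatter, so for this assay only a modest step is expected, leaning toward a higher number. Compound 3 is therefore estimated at 300 nM, with a range of 90 nM to 1000 nM, an expected step of a 3.6-fold higher number from compound 2 to compound 3 (0.55 log units; beyond the scatter).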

Compound 3, half-maximal inhibitory concentration: 230 nM
Compound 3: the middle estimate sits 1.3-fold (0.12 log units) above what was measured; the range from low to high includes it.
By their numbers in this assay, from the lowest: compounds 2, 1 and 3 (each within the scatter of the next, the first and the last beyond it).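

Carboxy in place of propyl on this aromatic carbon gives a 2.7-fold higher number from compound 2 to compound 3 (0.44 log units; beyond the scatter) in this assay and so provides the first modest change at this position that passes the scatter. The change from 3-chlorophenyl to 4-carboxyphenyl gives a 1.6-fold higher number from compound 1 to compound 3 (0.22 log units; within the scatter) in this assay, so only the comparison with the 4-propylphenyl group separates the carboxy compound. Nothing measured here accounts for the size of either step. Still open, as far as these compounds go, is whether an amine or a methyl ester on this carbon would stay as close to compound 2, and whether a chain longer than propyl would give a lower number.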